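A Methyl Group on the Ring Nitrogen of Compound 1

The compounds below may be only part of what the source reports. "The series", "measured", "known", "first", "only" and "open" are said of these compounds alone.

In an assay on isolated protein for inhibition of acid-sensing ion channel 3 (Homo sapiens), read by patch clamp, tested at 1 uM (a lower number here means less inhibition, a higher number more inhibition at the concentration tested (going by the name of the read-out)), compound 1 `N=C(N)c1ccc(-c2cc3cc(C(=N)N)ccc3[nH]2)cc1` gives 39%, the lowest of the three numbers measured. Compound 3 `Cc1cc(Cl)cc(-c2cc3cc(C(=N)N)ccc3[nH]2)c1` gives 87% in this assay, and compound 2 `N=C(N)c1ccc2[nH]c(-c3cc(F)cc(Br)c3)cc2c1` gives 93%; both stand well beyond the usual scatter above compound 1. Compound 4 `Cn1c(-c2ccc(C(=N)N)cc2)cc2cc(C(=N)N)ccc21` has not been measured. It differs from compound 1 in one place: methyl in place of hydrogen on an aromatic nitrogen. Within the data shown here, no pair of measured compounds differs by this same change, so the size of such a step is unknown; all three measured compounds keep the hydrogen on that ring nitrogen, and nothing measured shows what the methyl does there. Without such a comparison, the step is expected to be of modest size, in either direction, and probably not beyond the scatter: a number 4 percentage points lower from compound 1 to compound 4 (within the scatter). Compound 4 is therefore estimated to give about 35% in this assay, with a range from 10% to 65%.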

Compound 4, a percentage reported as inhibition, at one concentration (the size of the read-out at that concentration, not a potency): 14%
Compound 4: the middle estimate sits 21 percentage points above what was measured; low and high end bracket the measured number.
By their numbers in this assay, from the lowest: compound 4; then compound 1; then compounds 3 and 2 (each within the scatter of the next).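

In this assay, among these compounds, methyl in place of hydrogen on an aromatic nitrogen brings a number 25 percentage points lower from compound 1 to compound 4 (beyond the scatter), the first reading of any change at this position. This position therefore responds to substitution: one added carbon, with no ring, no hydrogen-bond donor or acceptor and no net charge in the entering group, moves the number beyond the usual scatter, and it moves it downwards. No measurement shown bears on why the number falls.

The compounds shown leave open whether an ethyl group, or a longer chain ending in an amine or a carboxylic acid, on the same nitrogen would lower the number further or raise it again. They also leave open whether methyl at this nitrogen would bring a similar drop to compound 2 or compound 3, which carry different groups elsewhere.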